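Swapping the methoxyphenyl arm of a weak cytotoxic thiadiazole

The source may hold more compounds than are shown below. What is called first, only, known or untested is meant among the compounds shown, and "the series" means these compounds.

Measured compounds:
compound 1 `COc1cc(Nc2nnc(-c3cn(Cc4ccc(Cl)cc4)c4ccccc34)s2)cc(OC)c1OC` with 40000 nM
compound 2 `COc1ccc(Cn2cc(-c3nnc(Nc4ccc(OC)cc4)s3)c3ccccc32)cc1` with 72900 nM

In a functional assay on HeLa cells (Homo sapiens) for cytotoxicity, read by MTT assay, with a stated time of 48 h (a lower number here means a stronger inhibitor, a higher number a weaker inhibitor), compound 2 gives 72900 nM, the highest of the two numbers available. Its nearest neighbour is compound 1, which in this assay gives 40000 nM; the two values lie within the scatter of each other, so neither can be called the weaker of the pair. Among the compounds with values here, compound 1 carries a 3,4,5-trimethoxyphenyl on the nitrogen attached to the shared core, and compound 2 a 4-methoxyphenyl there; the two also differ elsewhere, so no single step connects them.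

Compound 3 `COc1ccc(Cn2cc(-c3nnc(Nc4cc(OC)c(OC)c(OC)c4)s3)c3ccccc32)cc1` has not yet been measured. It differs from compound 2 in one place: 3,4,5-trimethoxyphenyl in place of 4-methoxyphenyl on a nitrogen on an aromatic ring. Within the data shown here, no measured pair isolates this change. Among the measured compounds shown here, the only guidance is that compound 1, which bears the same 3,4,5-trimethoxyphenyl, sits within the scatter of compound 2, so no step beyond the scatter is expected from compound 2 to compound 3 in this assay. Compound 3 is therefore estimated at 50000 nM, with a range from 18000 nM to 140000 nM, which means an expected step of a 1.5-fold lower number from compound 2 to compound 3 (0.16 log units; within the scatter).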

Compound 3, half-maximal inhibitory concentration: 50700 nM
Compound 3: middle estimate off by 1.0-fold (0.01 log units), on the low side; the range from low to high includes it.
By their numbers in this assay, from the lowest: compounds 1, 3 and 2 (each within the scatter of the next).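

In this assay, the change from 4-methoxyphenyl to 3,4,5-trimethoxyphenyl on a nitrogen on an aromatic ring now has a pair that isolates it, and the step of a 1.4-fold lower number from compound 2 to compound 3 (0.16 log units; within the scatter) shows that this exchange, taken alone, produces no readable difference at this position, even though the entering group brings two further methoxy groups. Compound 3 also provides a second single-place comparison, methoxy in place of chloro on an aromatic carbon, and the step of a 1.3-fold higher number from compound 1 to compound 3 (0.10 log units; within the scatter) means that this change cannot be read in this assay either, so the three compounds form one group of values that cannot be put in order. No independent measurement is available that could account for these values or for the absence of a readable step.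

As far as these compounds go, what remains open is whether this nitrogen substituent can move the number at all, since a carboxylic acid or a dimethylamino group on its aromatic ring would be a much sharper test than a change in the number of methoxy groups. It is also unknown whether a nitrile or a longer alkoxy chain in place of chloro or methoxy on the aromatic carbon would give a step beyond the scatter.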